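A Methyl Added Where Two Limits Already Stand

A few compounds are considered here, and "the series" means these few. Any claim that something is new, unique, unknown or untested is made for them only; others in the source may bear on it.

Measured compounds:
compound 1 `Cc1ccc(NC(=O)c2cccc(C(F)(F)F)c2)cc1OC1CCN(C(=O)c2ccncc2)CC1` — > 10000 nM
compound 2 `CCC(=O)N1CCC(Oc2cc(NC(=O)c3cccc(C(F)(F)F)c3)ccc2C)CC1` — > 10000 nM

In an ADME assay on BaF3 cells (Mus musculus) for antiproliferative activity (a higher number here means a weaker inhibitor of growth, a lower number a stronger inhibitor of growth), compound 1 gives > 10000 nM, which is a limit of the assay rather than a number. Compound 2 likewise gives > 10000 nM in this assay, again a limit. For the measured compounds named here, the only measured step, a step that the two limits leave unreadable from compound 1 to compound 2, cannot be read because of the limit of > 10000 nM in this assay, at which 2 of the 2 values shown sit. Compound 1 therefore stands at the limit, with no numerical position of its own.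

Compound 3 `Cc1ccc(NC(=O)c2ccc(C)c(C(F)(F)F)c2)cc1OC1CCN(C(=O)c2ccncc2)CC1` differs from compound 1 by methyl in place of hydrogen on an aromatic carbon. Going by the values given here, no measured step touches this part of the molecule, so the step carries no direct precedent. With both measured values sitting at the limit, compound 3 is expected to remain there as well, and the step of a number no higher from compound 1 to compound 3 (the limit leaves the size open) is expected to show no change beyond the scatter. Compound 3 is thus estimated at 10000 nM in this assay, within 3000 nM to 30000 nM, most likely reported only as a limit.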

Compound 3, concentration for 50% growth inhibition: 6390 nM
For compound 3 the middle estimate is 1.6-fold (0.19 log units) above the measured one; low and high end bracket the measured number.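

For the compounds shown here, compound 3 is the first compound here to give a number rather than a limit in this assay, so the aromatic carbon ortho to a trifluoromethyl group and para to a large group is a place where a small change can bring a compound within the range of the read-out. Putting methyl in place of hydrogen there gives an at least 1.5-fold lower number from compound 1 to compound 3 (0.19 log units; that floor lies within the scatter). That figure is only a floor, and the true size of the step stays unknown, since compound 1 sits at a limit: the limit of > 10000 nM in this assay, at which 2 of the 3 values shown sit.

From the compounds shown here alone, whether the same methyl would also bring compound 2, with its ethyl in place of pyridin-4-yl, down to a number remains open. So does what a chlorine atom, a methoxy group or an amine would do at this same position.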